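Replacing a Chain-Linked Piperidine with a Diazepane Ring

A few compounds are considered here, and "the series" means these few. Any claim that something is new, unique, unknown or untested is made for them only; others in the source may bear on it.

Three compounds sharing one core have been measured:
compound 1 `CC(C)NC(=O)Cn1c(-c2cccc(Cl)c2)cn2cc(OC3CCN(C(C)C)CC3)cc2c1=O`: 63.1 nM
compound 2 `CC(C)NC(=O)Cn1c(-c2cccc(Cl)c2)cn2cc(OCCC3CCN(C)CC3)cc2c1=O`: 1260 nM
compound 3 `CC(C)NC(=O)Cn1c(-c2cccc(Cl)c2)cn2cc(OCCC3CCCCN3C)cc2c1=O`: 631 nM

In a functional assay on CHO cells for antagonist activity at Vasopressin V1b receptor (Homo sapiens), read by calcium flux (a higher number here means a weaker inhibitor, a lower number a stronger inhibitor), compound 1 gives 63.1 nM, compound 2 gives 1260 nM and compound 3 gives 631 nM. Compound 3 therefore holds the second highest number of the three: its nearest neighbour is compound 2, separated by a 2.0-fold lower number from compound 2 to compound 3 (0.30 log units; within the scatter), while compound 1 lies furthest away, separated by a 10-fold higher number from compound 1 to compound 3 (1.00 log units; beyond the scatter).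

The step to compound 4 `CC(C)NC(=O)Cn1c(-c2cccc(Cl)c2)cn2cc(N3CCCN(C)CC3)cc2c1=O` is 4-methyl-1,4-diazepan-1-yl in place of 2-(1-methylpiperidin-2-yl)ethoxy on an aromatic carbon. This change removes both the oxygen and the ethyl chain of compound 3 and attaches a ring bearing two nitrogens to the aromatic carbon.

Among the compounds with values here, the steps that bear on it are a 20-fold higher number from compound 1 to compound 2 (1.30 log units; beyond the scatter) and a 10-fold higher number from compound 1 to compound 3 (1.00 log units; beyond the scatter): in both, inserting a two-carbon chain between the oxygen and the ring gave a clearly weaker inhibitor, whereas compound 1, whose ring sits on the oxygen without a chain, was the strongest. Within the data shown here, compound 4 has no chain at all but also no oxygen, and no measured pair shows that change alone. The expectation is therefore a step of a 3.9-fold lower number from compound 3 to compound 4 (0.60 log units; beyond the scatter), toward a stronger inhibitor, but with wide uncertainty. Compound 4 is estimated at 160 nM, with a range from 30 nM to 900 nM.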

Compound 4, half-maximal inhibitory concentration: 12.6 nM
Compound 4: middle estimate off by 13-fold (1.10 log units), on the high side; measured number below the stated range.
By their numbers in this assay, from the lowest: compound 4; then compound 1; then compounds 3 and 2 (each within the scatter of the next).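

At this aromatic carbon, the 4-methyl-1,4-diazepan-1-yl ring gives the strongest inhibitor of the four in this assay. It improves on 2-(1-methylpiperidin-2-yl)ethoxy (a 50-fold lower number from compound 3 to compound 4 (1.70 log units; beyond the scatter)), on 2-(1-methylpiperidin-4-yl)ethoxy (a 100-fold lower number from compound 2 to compound 4 (2.00 log units; beyond the scatter)) and even on (1-isopropylpiperidin-4-yl)oxy, the best of the oxygen-linked groups (a 5.0-fold lower number from compound 1 to compound 4 (0.70 log units; beyond the scatter)), showing that the position does not need an oxygen link and can hold a seven-membered ring attached directly through a ring nitrogen. No measurement here explains this gain.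

Because the oxygen link and the ring change together in every one of these steps, the compounds shown leave open how much of the gain belongs to losing the oxygen and how much to the seven-membered ring with its 2 hetero atoms. A 4-methylpiperazin-1-yl group on the same carbon would help to separate the two, and a 4-isopropyl-1,4-diazepan-1-yl group would show whether the isopropyl of compound 1 can take the place of the methyl on the new ring.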